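One Methyl Removed: Expected Cell Toxicity of Compound 4

The source may hold more compounds than are shown below. What is called first, only, known or untested is meant among the compounds shown, and "the series" means these compounds.

Of the compounds shown here, three have been measured in an ADME assay on Vero cells (Chlorocebus sabaeus) for cytotoxicity, read by MTT assay, with a stated time of 72 h; a higher number here means a weaker inhibitor, a lower number a stronger inhibitor. Compound 1 `O=[N+]([O-])c1c[nH]c(-c2nnc(Cc3ccc(F)c4ccccc34)o2)c1` gives 229000 nM, compound 2 `COc1cc(/C=C/c2nnc(-c3cc([N+](=O)[O-])cn3C)o2)ccc1O` gives 203000 nM, and compound 3 `Cn1cc([N+](=O)[O-])cc1-c1nnc(Cc2ccc(F)c3ccccc23)o1` gives 119000 nM. Compound 3 and compound 1 share a core and differ by hydrogen in place of methyl on an aromatic nitrogen; in this assay that change gave a 1.9-fold higher number from compound 3 to compound 1 (0.28 log units; within the scatter). Compound 4 `COc1cc(/C=C/c2nnc(-c3cc([N+](=O)[O-])c[nH]3)o2)ccc1O` has not yet been measured. It relates to compound 2 as compound 1 relates to compound 3, differing by hydrogen in place of methyl on an aromatic nitrogen, the same change at the same place. How the core of compound 2 differs from the core of compound 3 is not broken down here. Because the earlier step of a 1.9-fold higher number from compound 3 to compound 1 (0.28 log units; within the scatter) stayed within the scatter, the step in this assay is expected to be similarly small: a 1.5-fold higher number from compound 2 to compound 4 (0.17 log units; within the scatter). Compound 4 is therefore estimated at 300000 nM, most likely between 150000 nM and 600000 nM.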

Compound 4, half-maximal inhibitory concentration: 221000 nM
Estimate against measurement, compound 4: 1.4-fold (0.13 log units) above, and the stated range covers the measured number.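

In this assay, putting hydrogen in place of methyl on the aromatic nitrogen gave a 1.1-fold higher number from compound 2 to compound 4 (0.04 log units; within the scatter). Set beside the earlier step, the change carries from one core to the other without a readable difference: the same change on two cores in this assay, a 1.9-fold higher number (0.28 log units; within the scatter) from compound 3 to compound 1 and a 1.1-fold higher number (0.04 log units; within the scatter) from compound 2 to compound 4, 1.8-fold (0.25 log units) apart, within the scatter of two such steps. This shows that on these two cores the swap leaves the number within the scatter, but it does not show that the swap has any real effect of its own, and two cores cannot say how it would behave on a third.

The compounds shown carry only methyl or hydrogen on that nitrogen. As far as these compounds go, what an ethyl group, a longer chain or a chain ending in an amine would do there remains open.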